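Swapping the aryl group on a dihydro-type ring carbon

A few compounds are considered here, and "the series" means these few. Any claim that something is new, unique, unknown or untested is made for them only; others in the source may bear on it.

Compound 1 `COc1ccc(OC)c(C2=NOC(COc3ccc(-c4nnnn4-c4cc(OC)c(OC)c(OC)c4)cc3N)C2)c1` gives 3500 nM
Compound 2 `COc1ccc(-c2nnnn2-c2cc(OC)c(OC)c(OC)c2)cc1N` gives 3170 nM
Compound 3 `COc1cc(-n2nnnc2-c2ccc(OCC3CC(c4ccc(C(F)(F)F)cc4)=NO3)c(N)c2)cc(OC)c1OC` gives 1750 nM

All three values come from a functional assay on MDA-MB-231 cells (Homo sapiens) for cytotoxicity, read by MTT assay, with a stated time of 48 h; on this read-out lower numbers stand for stronger inhibition and higher numbers for weaker inhibition. There, compound 3 at 1750 nM lies within the scatter of both other compounds, so none of the three stands apart. Compound 4 `COc1cc(-n2nnnc2-c2ccc(OCC3CC(c4cccc(Cl)c4)=NO3)c(N)c2)cc(OC)c1OC` has not yet been measured. Its difference from compound 3 is 3-chlorophenyl in place of 4-(trifluoromethyl)phenyl on a carbon with a double bond to nitrogen, with the new group on a carbon with a double bond to nitrogen. Going by the values given here, one measured step bears on this place, a 2.0-fold lower number from compound 1 to compound 3 (0.30 log units; within the scatter), and it changes the aryl group on that same carbon. On that evidence, the expected 1.3-fold higher number from compound 3 to compound 4 (0.10 log units; within the scatter) should stay within the scatter in this assay. Compound 4 is estimated at 2200 nM, with an expected range of 1000 nM to 4700 nM.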

Compound 4, half-maximal inhibitory concentration: 2180 nM
For compound 4 the middle estimate is 1.0-fold (0.00 log units) above the measured one; low and high end bracket the measured number.
By their numbers in this assay, from the lowest: compounds 3, 4, 2 and 1 (each within the scatter of the next).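

In this assay, 3-chlorophenyl on the carbon with a double bond to nitrogen does not separate from 4-(trifluoromethyl)phenyl (a 1.2-fold higher number from compound 3 to compound 4 (0.10 log units; within the scatter)) or from 2,5-dimethoxyphenyl (a 1.6-fold lower number from compound 1 to compound 4 (0.21 log units; within the scatter)). Three aryl groups at this place now give values that lie within the scatter of one another. The full group bearing 3-chlorophenyl, in place of a hydrogen atom on the saturated chain carbon bound to an oxygen on an aromatic ring, does not separate either (a 1.5-fold lower number from compound 2 to compound 4 (0.16 log units; within the scatter)). No measurement is available to explain these results. As far as these compounds go, whether an amine or a carboxylic acid on the aryl ring would move the value beyond the scatter remains open.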